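Compound 3: acetyl in place of methyl

This account rests on a few compounds, and the source may have more. Where it says the series, first, only, none or still open, it means among the compounds named here.

In an ADME assay on HT-29 cells (Homo sapiens) for cytotoxicity, read by luminescence and CellTiter-Glo, with a stated time of 12 h (on this read-out lower numbers stand for higher toxicity in this test and higher numbers for lower toxicity in this test), compound 1 `Cc1cccc(NC(=O)Nc2cc(Oc3ccc4nc(NC(=O)C5CC5)sc4c3)ccc2F)c1` gives > 50000 nM, which is a limit of the assay and not a number. Its place in the series is therefore only (the limit of > 50000 nM in this assay, at which 2 of the 2 values shown sit). Compound 2 `CCOC(=O)c1cccc(NC(=O)Nc2cc(Oc3ccc4nc(NC(=O)C5CC5)sc4c3)ccc2F)c1` gives > 50000 nM, which is likewise a limit. For the measured compounds named here, the only measured step is a step that the two limits leave unreadable from compound 1 to compound 2, with ethoxycarbonyl in place of methyl on an aromatic carbon.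

Compound 3 `CC(=O)c1cccc(NC(=O)Nc2cc(Oc3ccc4nc(NC(=O)C5CC5)sc4c3)ccc2F)c1` differs from compound 1 by acetyl in place of methyl on an aromatic carbon, meta to a large group: acetyl in place of methyl on an aromatic carbon. Going by the values given here, the step to ethoxycarbonyl is the one measured change that bears on this, and it gives no size to carry over. No readable step is expected in this assay for this change, and no direction can be given, since compound 2 stays at the limit of > 50000 nM. The expected step is a number no higher from compound 1 to compound 3 (the limit leaves the size open), which means none beyond the scatter. For compound 3 the estimate is 50000 nM, with an expected range of 25000 nM to 100000 nM, and a report as a limit is the likeliest outcome.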

Compound 3, half-maximal cytotoxic concentration: > 50000 nM
Compound 3: no number, only a limit; the forecaster's own chance of this, stated with the estimate: 85%; the middle value lies on the limit itself.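

In this assay compound 3 gives > 50000 nM, a limit and not a number. No new step can be read among compound 1, compound 2 and compound 3: the limit of > 50000 nM in this assay, at which 3 of the 3 values shown sit.

The compounds shown leave open whether any group on this aromatic carbon changes the half-maximal cytotoxic concentration, and what number each of the three compounds would take.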